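Adding a Hydroxy Group to the Phenoxy Series

The source may hold more compounds than are shown below. What is called first, only, known or untested is meant among the compounds shown, and "the series" means these compounds.

Three measured compounds share a core that carries a pyridin-3-yl group on one saturated ring carbon and a longer side chain on another. Compound 1 `O=C(O)CC/C=C\CC1COC(c2cccnc2)OC1c1cccnc1` has a second pyridin-3-yl on the remaining saturated ring carbon; in a functional assay for inhibition, with Homo sapiens as the target (on this read-out higher numbers stand for weaker binding and lower numbers for tighter binding), compound 1 gives 759 nM. Compound 2 `O=C(O)CC/C=C\CC1COC(c2cccs2)OC1c1cccnc1` carries a thiophen-2-yl there instead, and compound 2 gives 1000 nM; the step of a 1.3-fold higher number from compound 1 to compound 2 (0.12 log units; within the scatter) is within the scatter. Compound 3 `CC(C)(Oc1ccccc1)C1OCC(C/C=C\CCC(=O)O)C(c2cccnc2)O1` places a phenoxy-bearing group on that carbon and gives 75.9 nM, the lowest of the three numbers, reached by a 10-fold lower number from compound 1 to compound 3 (1.00 log units; beyond the scatter) and by a 13-fold lower number from compound 2 to compound 3 (1.12 log units; beyond the scatter).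

Compound 4 `CC(C)(Oc1ccccc1O)C1OCC(C/C=C\CCC(=O)O)C(c2cccnc2)O1` differs from compound 3 in one place: hydroxy in place of hydrogen on an aromatic carbon. Within the data shown here, none of the measured steps touches a substituent on the phenyl ring itself; the two large steps exchange the whole group on the saturated ring carbon, and the small step swaps one aromatic ring for another. Among the measured compounds shown here, no measured step therefore bears directly on this change, and a step in this assay no larger than the scatter, in either direction, is the plainest expectation. Compound 4 is estimated at 80 nM, with a range from 30 nM to 250 nM. The step this estimate means, a 1.1-fold higher number from compound 3 to compound 4 (0.02 log units; within the scatter), is expected to fall within the usual scatter.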

Compound 4, dissociation constant: 95.5 nM
Compound 4: the middle estimate sits 1.2-fold (0.08 log units) below what was measured; the measured number falls inside the stated range.
By their numbers in this assay, from the lowest: compounds 3 and 4 (each within the scatter of the next); then compounds 1 and 2 (each within the scatter of the next).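

In this assay, adding a hydroxy group to the phenoxy ring, ortho to a large group, gives a 1.3-fold higher number from compound 3 to compound 4 (0.10 log units; within the scatter), so this read-out does not separate the two compounds. Among these compounds, the earlier steps exchanged whole groups on a saturated ring carbon, whereas this one is the first to change only a substituent on the phenyl ring, and it shows that replacing hydrogen with hydroxy at this place leaves the number within the scatter. The data shown offer no independent measurement that could explain this result.

A single substitution at a single place cannot show whether this position tolerates change in general, so a methoxy group, a fluorine atom, an amine or a carboxylic acid in the same place might give a similar number or a very different one. On these data alone, it also remains open whether the same hydroxy group would give a similar result elsewhere on the ring, or on the compounds that carry pyridin-3-yl or thiophen-2-yl instead of the phenoxy-bearing group.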